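This account rests on a few compounds, and the source may have more. Where it says the series, first, only, none or still open, it means among the compounds named here.

Three compounds have been measured in a functional assay on U-937 cells (Homo sapiens) for cytotoxicity, read by MTT assay, with a stated time of 24 h; on this read-out higher numbers stand for weaker inhibition and lower numbers for stronger inhibition:

Compound 1 `CN1CCN(CCCCCOc2c(Br)cc(Br)cc2Oc2ccc(Br)cc2Br)CC1` gives 49.1 ug/mL.
Compound 2 `COc1c(Br)cc(Br)cc1Oc1ccc(Br)cc1Br` gives 34.5 ug/mL.
Compound 3 `Cc1ccc(S(=O)(=O)n2nc(N3CCN(CCCCCOc4c(Br)cc(Br)cc4Oc4ccc(Br)cc4Br)CC3)c3cc([N+](=O)[O-])ccc32)cc1` gives 68.5 ug/mL.

On these numbers compound 1 stands between the other two: its nearest neighbour is compound 3, and its furthest is compound 2, yet both gaps fall within the scatter of repeated measurements, so the three values cannot be told apart. Compound 4 `OCCOc1c(Br)cc(Br)cc1Oc1ccc(Br)cc1Br` has not yet been measured. It differs from compound 1 as follows: hydroxy in place of 3-(4-methylpiperazin-1-yl)propyl on a saturated chain carbon, two bonds along the chain from an oxygen on an aromatic ring. For the measured compounds named here, no measured pair shows this change directly, and with all three known values lying together, no step beyond the scatter is expected in this assay in either direction. The value of compound 4 is estimated at 42 ug/mL, between 20 ug/mL and 90 ug/mL, which means an expected step of a 1.2-fold lower number from compound 1 to compound 4 (0.07 log units; within the scatter).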

Compound 4, half-maximal inhibitory concentration: 34.5 ug/mL
The estimate for compound 4 lay 1.2-fold (0.09 log units) above the measured number; low and high end bracket the measured number.
By their numbers in this assay, from the lowest: compounds 2, 4, 1 and 3 (each within the scatter of the next).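

In this assay, the position now has direct steps: hydroxy in place of 3-(4-methylpiperazin-1-yl)propyl gives a 1.4-fold lower number from compound 1 to compound 4 (0.15 log units; within the scatter), and hydroxymethyl in place of hydrogen gives no change at the digits printed from compound 2 to compound 4 (within the scatter). Neither the large group with its six-membered ring nor the small hydroxy-bearing chain produces a step beyond the scatter at this place. Nothing available accounts for these results. Still open, going by these compounds, is whether a carboxylic acid or a primary amine in place of the hydroxy, or a longer chain carrying hydroxy, would produce a step beyond the scatter in this assay.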